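Sulfonyl ethyl to trifluoromethyl swap: cytotoxicity working notes

The source may hold more compounds than are shown below. What is called first, only, known or untested is meant among the compounds shown, and "the series" means these compounds.

Measured so far in an ADME assay on RAW264.7 cells (Mus musculus) for cytotoxicity, read by MTT assay, with a stated time of 48 h; a lower number here means a stronger inhibitor, a higher number a weaker inhibitor:

compound 1 `CCS(=O)(=O)Nc1ccc(NC(=O)c2ccc(C#N)cc2)cc1C`: 109000 nM
compound 2 `CCS(=O)(=O)Nc1ccc(NC(=O)c2cccc(C(F)(F)F)c2)cc1C`: 114000 nM
compound 3 `Cc1cc(NC(=O)c2ccc(C#N)cc2)ccc1NS(=O)(=O)C(F)(F)F`: 135000 nM

Compound 3 is obtained from compound 1 by trifluoromethyl in place of ethyl on a sulfonyl sulfur. In this assay this gives a 1.2-fold higher number from compound 1 to compound 3 (0.09 log units; within the scatter), so the swap on the sulfonyl sulfur left the read-out essentially where it was. Compound 1 and compound 2 carry the same ethylsulfonyl group but differ elsewhere in more than one place; the difference between the two cores is not broken down here. In this assay the values of compound 1 and compound 2 lie within the scatter of each other, and compound 2 also lies within the scatter of compound 3, so the three measured compounds cannot be ordered against one another.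

Compound 4 `Cc1cc(NC(=O)c2cccc(C(F)(F)F)c2)ccc1NS(=O)(=O)C(F)(F)F` is not yet measured. It is obtained from compound 2 by trifluoromethyl in place of ethyl on a sulfonyl sulfur, the same change as from compound 1 to compound 3, at the same place with the same neighbours. Among the compounds with values here, only one earlier instance of this change is available, so any expectation rests on that single pair. Compound 4 is expected to move from compound 2 by a 1.1-fold higher number from compound 2 to compound 4 (0.06 log units; within the scatter) because the earlier step of a 1.2-fold higher number from compound 1 to compound 3 (0.09 log units; within the scatter) stayed within the scatter. Compound 4 is therefore estimated at 130000 nM in this assay, with a plausible range from 80000 nM to 220000 nM.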

Compound 4, half-maximal inhibitory concentration: 8720 nM
For compound 4 the middle estimate is 15-fold (1.17 log units) above the measured one; the whole stated range lies above it.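

In this assay, trifluoromethyl in place of ethyl on a sulfonyl sulfur gives a 13-fold lower number from compound 2 to compound 4 (1.12 log units; beyond the scatter), a large step on the core of compound 2, and it does not match the step seen for the same change on the core of compound 1: the same change on two cores in this assay, a 1.2-fold higher number (0.09 log units; within the scatter) from compound 1 to compound 3 and a 13-fold lower number (1.12 log units; beyond the scatter) from compound 2 to compound 4, 16-fold (1.21 log units) apart, beyond the scatter of two such steps

The change therefore does not carry over as a fixed step between these two cores, and the result on one core gave no reliable guide to the result on the other. Within the data shown here, this does not show why the two steps part, which feature of the cores matters, or how the change would behave on any further core, since the evidence consists of only two pairs and the cores differ in more than one place.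

The compounds shown leave open whether the large step on the core of compound 2 is specific to trifluoromethyl or would also appear with another group on the sulfonyl sulfur, such as methyl or a longer chain such as propyl. They also leave open which part of the difference between the two cores goes with the step, which would need cores that differ from each other in one place only.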